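Swapping a pyridinyl for a phenyl on the thioether

The source may hold more compounds than are shown below. What is called first, only, known or untested is meant among the compounds shown, and "the series" means these compounds.

Compound 1: `CC(Sc1nc2c(cnn2C)c(=O)n1-c1ccccc1)c1ccccn1` — 97%
Compound 2: `CC(Sc1nc2nn(C3COC3)cc2c(=O)n1-c1ccccc1)c1ccccn1` — 99%
Compound 3: `CC(Sc1nc2nn(CC3COC3)cc2c(=O)n1-c1ccccc1)c1ccccc1` — 87%

Of the compounds shown here, three sharing one core have been tested in an assay on PEO1 cells for inhibition of Retinaldehyde dehydrogenase 3 (Homo sapiens), read by flow cytometry, with a stated time of 30 min, tested at 1 uM; a higher number here means more inhibition at the concentration tested (going by the name of the read-out), a lower number less inhibition. Compound 1 gives 97% in this assay, which places it second highest of the three numbers. Its nearest neighbour is compound 2, whose value of 99% lies within the usual scatter of compound 1; the furthest is compound 3, whose 87% also stays within that scatter. Among the compounds with values here, no single-point step between measured compounds is available, so none of these gaps can be called a real difference.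

The account now turns to compound 4, `C[C@H](Sc1nc2c(cnn2C)c(=O)n1-c1ccccc1)c1ccccc1`, which has not yet been measured in this assay. It differs from compound 1 in one place: 1-phenylethyl in place of 1-(pyridin-2-yl)ethyl on a sulfur

A 1-phenylethyl on the sulfur is already present in one of the measured compounds, although that compound differs from compound 1 elsewhere as well. That compound is compound 3, and its value of 87% shows that such a group is compatible with strong inhibition at this concentration. On that basis the step of a number 8 percentage points lower from compound 1 to compound 4 (within the scatter) is expected to be small, downward if anything, and not beyond the scatter. Compound 4 is therefore estimated to give 89% in this assay, with a likely range from 72% to 99%.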

Compound 4, a percentage reported as inhibition, at one concentration (the size of the read-out at that concentration, not a potency): 2%
Compound 4: the middle estimate sits 87 percentage points above what was measured; the measured number lies below the stated range.
By their numbers in this assay, from the lowest: compound 4; then compounds 3, 1 and 2 (each within the scatter of the next, the first and the last beyond it).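

In this assay, within the data shown here, exchanging 1-(pyridin-2-yl)ethyl for 1-phenylethyl on a sulfur produces a number 95 percentage points lower from compound 1 to compound 4 (beyond the scatter), so the first readable step at this position shows that, on the core of compound 1, the result depends strongly on this group. The two groups have the same heavy-atom count, but the one that leaves has a ring nitrogen and a hydrogen-bond acceptor, while the one that enters has a carbon-only ring, no acceptor and a defined stereocentre, and this single step cannot separate these differences. Nothing available bears on why the number falls so far.

The compounds shown leave open whether the ring nitrogen, the defined stereocentre or both account for the step, and the opposite stereoisomer of compound 4 and a defined stereoisomer of compound 1 would bear directly on that question. They also leave open how the position responds to other groups on the sulfur, such as 1-(pyridin-3-yl)ethyl, or to a methoxy group or an amine on the phenyl ring of 1-phenylethyl.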